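This account rests on a few compounds, and the source may have more. Where it says the series, first, only, none or still open, it means among the compounds named here.

Compound 1 `CC(=O)N[C@@H](CSC(=O)Nc1ccccc1F)C(=O)O` and compound 2 `COc1ccc(NC(=O)SC[C@H](NC(C)=O)C(=O)O)cc1` share one core and were tested in a functional assay on GC3/C1 cells (Homo sapiens) for cytotoxicity, read by MTT assay, with a stated time of 6 days; on this read-out lower numbers stand for stronger inhibition and higher numbers for weaker inhibition. Compound 1 gives > 200000 nM, a limit of the assay and not a number. Compound 2 gives > 200000 nM, which is likewise a limit. Compound 2 therefore has no exact place on the scale, and the whole record so far is the limit of > 200000 nM in this assay, at which 2 of the 2 values shown sit.

Compound 3 `CC(=O)N[C@@H](CSC(=O)Nc1ccc(I)cc1)C(=O)O` keeps the core of compound 2 but carries iodo in place of methoxy on an aromatic carbon, para to a large group: iodo in place of methoxy on an aromatic carbon. For the measured compounds named here, no pair of measured compounds differing in one place is available, so no measured step guides the expectation. The expectation therefore rests on the limit of compound 2, > 200000 nM, and none beyond the scatter is foreseen in this assay. The expected change is a number no higher from compound 2 to compound 3 (the limit leaves the size open). For compound 3 the estimated value is 200000 nM. The expected range for compound 3 runs from 80000 nM to 400000 nM, and the assay may well report only a limit again.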

Compound 3, half-maximal inhibitory concentration: > 200000 nM
Compound 3: no number, only a limit; the forecaster's own chance of this, stated with the estimate: 70%; the middle value lies on the limit itself.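

In this assay compound 2 and compound 3 both give only a limit and not a number, so no step can be read for iodo in place of methoxy on the aromatic carbon. The compounds shown leave open where any of them stands on the scale, and whether any change to the shared core would give a number: the limit of > 200000 nM in this assay, at which 3 of the 3 values shown sit.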